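Swapping a Pyridine Ring for an Open-Chain Oxime Ether

The source may report more compounds than this note shows. Statements on the series, on what has been measured and on what is new or still open speak of the compounds shown alone.

Compound 1, `Cc1cc(-c2ccccc2NCC2=NCCN2)on1`: 95.5 nM
Compound 2, `Cc1ccsc1-c1ccccc1NCC1=NCCN1`: 112 nM
Compound 3, `c1ccc(-c2ccccc2NCC2=NCCN2)nc1`: 30.2 nM

These three compounds share one core and differ only in the group attached on an aromatic carbon. In a functional assay for activation of Alpha-1B adrenergic receptor (Homo sapiens), read by calcium flux (a lower number here means that less compound is needed, a higher number that more compound is needed for the effect), compound 3 gives the lowest number of the three: a 3.2-fold lower number from compound 1 to compound 3 (0.50 log units; beyond the scatter) and a 3.7-fold lower number from compound 2 to compound 3 (0.57 log units; beyond the scatter), both beyond the scatter, whereas a 1.2-fold higher number from compound 1 to compound 2 (0.07 log units; within the scatter). Compound 4, `CCO/N=C(\C)c1ccccc1NCC1=NCCN1`, has not yet been measured. Its difference from compound 3 is a group of 6 heavy atoms (4 carbon, 1 nitrogen, 1 oxygen; no ring) in place of a group of 6 heavy atoms (5 carbon, 1 nitrogen; one six-membered aromatic ring with 1 hetero atom), on an aromatic carbon. The two measured steps that bear on this position each exchanged one aromatic ring for another; none removed the ring in favour of an open chain, so they inform this step only loosely. Because a 3.2-fold lower number from compound 1 to compound 3 (0.50 log units; beyond the scatter) and a 3.7-fold lower number from compound 2 to compound 3 (0.57 log units; beyond the scatter) both ran toward lower numbers on arrival of the pyridin-2-yl group, its departure is expected to move the number back up, most likely by a modest amount, toward the region of compounds 1 and 2. Compound 4 is therefore estimated at 100 nM, with a range of 40 nM to 300 nM. The expected step is a 3.3-fold higher number from compound 3 to compound 4 (0.52 log units; beyond the scatter).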

Compound 4, half-maximal effective concentration: < 5020 nM
Compound 4 was reported as a limit; the forecaster's own chance of this, stated with the estimate: 5%; the middle value is on the limit's open side.
By their numbers in this assay, from the lowest: compound 3; then compounds 1 and 2 (each within the scatter of the next).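

In this assay compound 4 gives < 5020 nM, which is a limit of the assay and not a number. Among these compounds, no step from compound 1, compound 2 or compound 3 to compound 4 can be read. The compounds shown leave open how the number for compound 4, with its group without a ring, truly compares with those of the three ring-bearing compounds.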